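The compounds below may be only part of what the source reports. "The series", "measured", "known", "first", "only" and "open" are said of these compounds alone.

Compound 1 `Cc1nc(C(=O)NCc2ccccc2)c(O)c(=O)n1C` in an ADME assay on HepG2 cells (Homo sapiens) for cytotoxicity, in the presence of a further agent that is not named here (a higher number here means a weaker inhibitor, a lower number a stronger inhibitor), gives > 100000 nM, a limit of the assay.
Compound 2 `Cn1c(Cc2ccccc2C(F)(F)F)nc(C(=O)Nc2ccccc2)c(O)c1=O` in this assay gives > 100000 nM, a limit of the assay.
Compound 3 `Cn1c(Cc2ccccc2C(F)(F)F)nc(C(=O)NCc2ccccc2)c(O)c1=O` in this assay gives > 100000 nM, a limit of the assay.

On the numbers shown, compound 2 stands only at a limit in this assay, and so do the other two measured compounds: all three sit at the limit of > 100000 nM in this assay, at which 3 of the 3 values shown sit. Compound 4 `Cn1c(Cc2ccccc2C(F)(F)F)nc(C(=O)NCc2ccc(F)cc2)c(O)c1=O` remains to be measured in this assay. It differs from compound 2 by 4-fluorobenzyl in place of phenyl on an amide-type nitrogen.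

Among the measured compounds shown here, two measured steps bear on this change. a step that the two limits leave unreadable from compound 2 to compound 3 alters the same amide-type nitrogen, and a step that the two limits leave unreadable from compound 1 to compound 3 alters the other side of the shared core. Both steps run between limits, so neither has a readable size or direction. No step beyond the scatter is therefore expected in this assay; the expected step is a step that the limit leaves unreadable from compound 2 to compound 4. Compound 4 is estimated at 150000 nM, within a range from 50000 nM to 500000 nM, and most likely this assay will again report only a limit.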

Compound 4, half-maximal inhibitory concentration: > 100000 nM
Compound 4: a limit, no number; the forecaster's own chance of this, stated with the estimate: 85%; the middle value is on the limit's open side.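

In this assay compound 4 gives > 100000 nM, a limit of the assay, so neither step to it, from compound 2 or from compound 3, can be read. The compounds shown leave open whether any change to this series gives a readable value in this assay.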